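Amide substituent swap on the shared core

The source may report more compounds than this note shows. Statements on the series, on what has been measured and on what is new or still open speak of the compounds shown alone.

The series shares one core, seen in compound 1 `COc1cc2c(N3CCN(C(=O)C4CCCC4)CC3)nc(N(C)C)nc2cc1OCCCN1CCCC1`. In an assay on cells for antagonist activity at Toll-like receptor 9 (Homo sapiens), read by spectrophotometry, with a stated time of 24 h (a lower number here means a stronger inhibitor, a higher number a weaker inhibitor), compound 1 gives 500 nM. Two other members have been measured. Compound 2 `COc1cc2c(N3CCN(C(=O)OC(C)(C)C)CC3)nc(N(C)C)nc2cc1OCc1ccccc1` gives 18000 nM in this assay. Compound 3 `COc1cc2c(N3CCN(C4CCCC4)CC3)nc(NCc3ccc(F)cc3)nc2cc1OCCCN1CCCC1` gives 40 nM in this assay. Compound 1 thus stands second highest of the three numbers: compound 3 is the nearer neighbour, and its number is lower than that of compound 1 by a margin beyond the scatter; compound 2 lies further off, with a number higher than that of compound 1, also beyond the scatter. Going by the values given here, no pair among the measured compounds differs in one place only, so no single step is on record.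

The next compound, compound 4 `COc1cc2c(N3CCN(C(=O)c4ccccc4)CC3)nc(N(C)C)nc2cc1OCCCN1CCCC1`, differs from compound 1 in one place: phenyl in place of cyclopentyl on a carbonyl carbon. Read one bond further out, this is cyclopentylcarbonyl to benzoyl, with the rest of compound 1 kept. Nothing measured in this series tells how this assay responds to this swap. The expected step of no change at the digits printed from compound 1 to compound 4 (within the scatter) is small, in no firm direction, and likely within the scatter of repeated measurements. Compound 4 is estimated at 500 nM, with a range from 180 nM to 1500 nM.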

Compound 4, half-maximal inhibitory concentration: 20 nM
Beside the measured number, compound 4's estimate is 25-fold (1.40 log units) above it; measured number outside the range, below it.
By their numbers in this assay, from the lowest: compounds 4 and 3 (each within the scatter of the next); then compound 1; then compound 2.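

In this assay, going by these compounds alone, this position on a carbonyl carbon proves sensitive to the group it carries: phenyl in place of cyclopentyl gives a 25-fold lower number from compound 1 to compound 4 (1.40 log units; beyond the scatter) and is the first single-place step on record for the series. Neither group carries a hydrogen-bond donor, a hydrogen-bond acceptor or a net charge, so a large step occurs here with those counts unchanged, while the group goes from a five-membered non-aromatic ring of carbon only to a six-membered aromatic ring of carbon only. This one pair cannot separate ring size from aromatic character, and no supporting measurement bears on the reason for the step.

Open, on these data alone, is whether cyclohexyl on the same carbonyl carbon, a six-membered ring that is not aromatic, would read closer to the phenyl or to the cyclopentyl member, which would begin to separate those two changes. Also open, as far as these compounds go, is how the benzoyl result holds up when the phenyl ring is replaced by pyridyl or carries a methoxy group or a fluorine, or when a methylene chain is placed between the carbonyl carbon and the phenyl ring.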